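The compounds below may be only part of what the source reports. "The series", "measured", "known", "first", "only" and "open" are said of these compounds alone.

Measured compounds in an assay on isolated protein for inhibition of bone morphogenetic protein 1 (Homo sapiens); on this read-out higher numbers stand for weaker inhibition and lower numbers for stronger inhibition:
compound 1 `COc1ccc(S(=O)(=O)N(Cc2cc(C)on2)[C@H](C)C(=O)NO)cc1`, 230 nM
compound 2 `COc1ccc(S(=O)(=O)N(Cc2ccc(Br)cc2)[C@H](C)C(=O)NO)cc1`, 37 nM
compound 3 `COc1ccc(S(=O)(=O)N(Cc2ccc(F)c(F)c2)[C@H](C)C(=O)NO)cc1`, 76 nM

Compound 3 holds the second highest of the three numbers: a 2.1-fold higher number from compound 2 to compound 3 (0.31 log units; beyond the scatter) places it behind compound 2, while a 3.0-fold lower number from compound 1 to compound 3 (0.48 log units; beyond the scatter) places it ahead of compound 1. Compound 4 `COc1ccc(S(=O)(=O)N(Cc2ccc(C(C)C)cc2)[C@H](C)C(=O)NO)cc1` differs from compound 3 in one place: 4-isopropylphenyl in place of 3,4-difluorophenyl on a saturated chain carbon bound to a sulfonamide nitrogen. For the measured compounds named here, the steps that bear on this change are a 6.2-fold lower number from compound 1 to compound 2 (0.79 log units; beyond the scatter) and a 2.1-fold higher number from compound 2 to compound 3 (0.31 log units; beyond the scatter), both modest; together they show that the group on the saturated chain carbon bound to the sulfonamide nitrogen shifts the number within a narrow band, with compound 2 lowest. Compound 4 is therefore expected to fall between compound 3 and compound 2, a modest downward step a 1.7-fold lower number from compound 3 to compound 4 (0.23 log units; within the scatter). For compound 4 the estimate in this assay is 45 nM, with a range of 15 nM to 130 nM.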

Compound 4, half-maximal inhibitory concentration: 230 nM
For compound 4 the middle estimate is 5.1-fold (0.71 log units) below the measured one; measured number above the stated range.
By their numbers in this assay, from the lowest: compound 2; then compound 3; then compounds 1 and 4 (each within the scatter of the next).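

At the saturated chain carbon bound to a sulfonamide nitrogen, a six-membered aromatic ring of carbon alone does not secure a low number: 4-isopropylphenyl in place of 3,4-difluorophenyl gives a 3.0-fold higher number from compound 3 to compound 4 (0.48 log units; beyond the scatter), and isopropyl in place of bromo gives a 6.2-fold higher number from compound 2 to compound 4 (0.79 log units; beyond the scatter). The group on the aromatic carbon therefore matters as much as the ring itself, since 4-isopropylphenyl in place of 5-methyl-1,2-oxazol-3-yl gives no change at the digits printed from compound 1 to compound 4 (within the scatter). Nothing at hand accounts for this rise. Open, going by these compounds, is how chloro, methoxy or a nitrile would read in place of bromo on that aromatic carbon.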